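The compounds below may be only part of what the source reports. "The series", "measured", "known", "first", "only" and "open" are said of these compounds alone.

Working notes on the series. Compound 1 `Cn1cncc1CN1CC(N(CC2CCN(C(=O)C3CCCC3)CC2)S(=O)(=O)c2ccccn2)Cc2cc(C#N)ccc21` and compound 2 `Cn1cncc1CN1CC(N(CC2CCN(C(=O)c3cccs3)CC2)S(=O)(=O)c2ccccn2)Cc2cc(C#N)ccc21` share one core and differ only at the group on a carbonyl carbon. For the measured compounds named here, in an ADME assay on Caco-2 cells (Homo sapiens) for permeability, in the apical to basolateral direction (a higher number here means that the compound crosses the layer faster, a lower number that the compound crosses the layer more slowly), compound 1 gives 0.5 10^-6 cm/s, and compound 2 gives 0.5 10^-6 cm/s; the step of no change at the digits printed from compound 1 to compound 2 (within the scatter) puts the two level within the scatter, so compound 1 stands at the same low level as its only measured neighbour.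

Compound 3 `Cn1cncc1CN1CC(N(CC2CCN(C(=O)Nc3ccc(Br)cc3)CC2)S(=O)(=O)c2ccccn2)Cc2cc(C#N)ccc21` is not yet measured. Its change from compound 1 is (4-bromophenyl)amino in place of cyclopentyl on a carbonyl carbon. Going by the values given here, the only step that bears on this position is no change at the digits printed from compound 1 to compound 2 (within the scatter), which was flat, so one exchange at this carbonyl carbon has left permeability unchanged; no measured step covers the entry of an amino-linked aryl group or a hydrogen-bond donor here. The expectation for compound 3 in this assay is therefore a step of a 1.3-fold lower number from compound 1 to compound 3 (0.10 log units; within the scatter), flat or slightly downward, not clearly beyond the scatter. Compound 3 is estimated at 0.4 10^-6 cm/s, with a range from 0.15 10^-6 cm/s to 1.2 10^-6 cm/s.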

Compound 3, apparent permeability: 0.6 10^-6 cm/s
The estimate for compound 3 lay 1.5-fold (0.18 log units) below the measured number; measured number inside the range.
By their numbers in this assay, from the lowest: compounds 1, 2 and 3 (each within the scatter of the next).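

In this assay the exchange of cyclopentyl for (4-bromophenyl)amino on a carbonyl carbon gives a 1.2-fold higher number from compound 1 to compound 3 (0.08 log units; within the scatter) and the exchange of thiophen-2-yl for the same group gives a 1.2-fold higher number from compound 2 to compound 3 (0.08 log units; within the scatter) with no further shift to report. This position now carries three different groups, one of them with a hydrogen-bond donor and a bromine, and compounds 1, 2 and 3 stand level within the scatter. Nothing available here accounts for this level.

As far as these compounds go, whether a carboxylic acid or a primary amine on this carbonyl carbon would stay at the same level remains open. So does whether a change elsewhere on the shared core, such as exchange of the nitrile for another group, would move the number at all.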